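A few compounds are considered here, and "the series" means these few. Any claim that something is new, unique, unknown or untested is made for them only; others in the source may bear on it.

Measured compounds:
compound 1, `CN(c1ccc2cc(NC(=O)CCc3ccc(C(F)(F)F)cc3)ccc2n1)C1CCCCC1`, which in an assay on isolated protein for displacement of a labelled ligand from melanin-concentrating hormone receptor 1 (Homo sapiens) (on this read-out lower numbers stand for stronger inhibition and higher numbers for weaker inhibition), gives 18 nM;
compound 2, `O=C(CCc1ccc(C(F)(F)F)cc1)Nc1ccc2nc(N3CC4CCC3C4)ccc2c1`, which in this assay gives 1 nM;
compound 3, `CN(c1ccc2cc(NC(=O)CCc3ccc(C(F)(F)F)cc3)ccc2n1)C1CCCC1`, which in this assay gives 2 nM.

Compound 3 stands second highest of the three numbers. Its nearest neighbour is compound 2, with a 2.0-fold higher number from compound 2 to compound 3 (0.30 log units; within the scatter), while compound 1 sits furthest away, with a 9.0-fold lower number from compound 1 to compound 3 (0.95 log units; beyond the scatter). Compound 4, `CC(=O)NC1CCN(c2ccc3cc(NC(=O)CCc4ccc(C(F)(F)F)cc4)ccc3n2)C1`, has not been measured. It differs from compound 3 in one place: 3-acetamidopyrrolidin-1-yl in place of cyclopentyl(methyl)amino on an aromatic carbon.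

For the measured compounds named here, none of the measured steps carries an acetamido group or a hydrogen-bond donor into this position, so the bearing of earlier steps is indirect. The step of a 9.0-fold lower number from compound 1 to compound 3 (0.95 log units; beyond the scatter) shows that the size of the ring on the nitrogen matters a great deal, and an 18-fold lower number from compound 1 to compound 2 (1.26 log units; beyond the scatter) shows a large gain for a bicyclic amine, yet a 2.0-fold higher number from compound 2 to compound 3 (0.30 log units; within the scatter) shows two rather different amines within the scatter of one another. The amine position therefore seems tolerant of change, but the new group is larger and more polar in count than anything measured. A modest loss is expected, and compound 4 is estimated at 6 nM, within 1.5 nM to 30 nM, corresponding to an expected 3.0-fold higher number from compound 3 to compound 4 (0.48 log units; beyond the scatter).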

Compound 4, half-maximal inhibitory concentration: 5 nM
Compound 4: middle estimate off by 1.2-fold (0.08 log units), on the high side; measured number inside the range.
By their numbers in this assay, from the lowest: compounds 2 and 3 (each within the scatter of the next); then compound 4; then compound 1.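

In this assay, the position on the aromatic carbon next to the ring nitrogen proves to accept 3-acetamidopyrrolidin-1-yl, a group with a hydrogen-bond donor where cyclopentyl(methyl)amino has none, at only a modest cost (a 2.5-fold higher number from compound 3 to compound 4 (0.40 log units; beyond the scatter)). The cost is larger against the bicyclic amine of compound 2 (a 5.0-fold higher number from compound 2 to compound 4 (0.70 log units; beyond the scatter)), yet the new group still gives a lower number than the cyclohexyl(methyl)amino group of compound 1 (a 3.6-fold lower number from compound 1 to compound 4 (0.56 log units; beyond the scatter)). Adding the acetamido group and its extra atoms therefore leaves the number inside the range already spanned by the earlier amines, so this position does not demand a simple carbon-rich amine.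

As far as these compounds go, whether the step comes from the acetamido group itself or from the pyrrolidine ring that carries it stays open, as does what 3-aminopyrrolidin-1-yl or a pyrrolidine bearing a carboxylic acid would give in its place. Nothing at hand explains why the number moves with any of these groups.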